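Pyridazinone acetamides: furan for fluorophenyl at the benzylic position

The source may report more compounds than this note shows. Statements on the series, on what has been measured and on what is new or still open speak of the compounds shown alone.

Measured so far:
compound 1 `COc1cccc(Cc2cc(-c3ccc(Cl)cc3)nn(CC(=O)Nc3ccc(F)cc3)c2=O)c1` — > 50000 nM
compound 2 `Cc1cc(Cc2cccc(F)c2)c(=O)n(CC(=O)Nc2ccc(Br)cc2)n1` — > 50000 nM

Both values come from an assay on HL-60 cells for agonist activity at N-formyl peptide receptor 3 (Homo sapiens), read by calcium flux; on this read-out lower numbers stand for an effect already at smaller amounts and higher numbers for an effect only at larger amounts of compound. For compound 1 the figure > 50000 nM is a limit of the assay, not a number. For compound 2 the figure > 50000 nM is likewise a limit. Among the measured compounds shown here, compound 2 therefore stands at the limit of > 50000 nM in this assay, at which 2 of the 2 values shown sit; no ordering between compound 1 and compound 2 can be read from these two limits, and no step between measured compounds is available.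

Compound 3 `Cc1cc(Cc2ccoc2)c(=O)n(CC(=O)Nc2ccc(Br)cc2)n1` is not yet measured in this assay. It differs from compound 2 by furan-3-yl in place of 3-fluorophenyl on a saturated chain carbon bound to an aromatic carbon. For the measured compounds named here, since the only measurements are limits, there is nothing to anchor the size of this step; the expectation is that the change from compound 2 to compound 3 lands near the limit again, with no shift beyond the scatter established either way, expressed as a step that the limit leaves unreadable from compound 2 to compound 3. Compound 3 is accordingly estimated at 80000 nM, with a range from 8000 nM to 500000 nM, and a high chance that the assay once more reports only a limit.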

Compound 3, half-maximal effective concentration: > 50000 nM
Compound 3 gave a limit, no number; the forecaster's own chance of this, stated with the estimate: 85%; the middle value is on the limit's open side.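

No step can be read between compound 2 and compound 3 in this assay, since each gives only a limit and not a number: the limit of > 50000 nM in this assay, at which 3 of the 3 values shown sit.

The compounds shown leave open whether furan-3-yl and 3-fluorophenyl differ at all in this assay, and whether any change to this series gives a measurable value there.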